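Triazole substituent exchange toward the sulfonamide analogue

The source may report more compounds than this note shows. Statements on the series, on what has been measured and on what is new or still open speak of the compounds shown alone.

Measured compounds in a functional assay on MCF7 cells (Homo sapiens) for antiproliferative activity, read by MTT assay, with a stated time of 72 h; on this read-out lower numbers stand for stronger inhibition and higher numbers for weaker inhibition:
compound 1 `O=C1O[C@H]([C@@H](O)Cn2cc(CNS(=O)(=O)c3ccc(Cl)cc3F)nn2)C(OCc2ccccc2)=C1OCc1ccccc1`: 3390 nM
compound 2 `C[Si](C)(C)c1cn(C[C@H](O)[C@H]2OC(=O)C(OCc3ccccc3)=C2OCc2ccccc2)nn1`: 12100 nM
compound 3 `Cc1ccc(-c2cn(C[C@H](O)[C@H]3OC(=O)C(OCc4ccccc4)=C3OCc3ccccc3)nn2)cc1`: > 100000 nM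

For compound 3 the value is a limit of this assay, not a number, namely (the limit of > 100000 nM in this assay, at which 1 of the 3 values shown sits). Going by the values given here, compound 3 is the only compound of the three whose value is such a limit. Among the compounds with values here, the one single-point step measured so far, an at least 8.2-fold higher number from compound 2 to compound 3 (0.91 log units; beyond the scatter), runs toward that limit, so the change from compound 3 back to a smaller substituent is read in reverse.

Compound 4 `O=C1O[C@H]([C@@H](O)Cn2cc(CNS(=O)(=O)c3ccc(Cl)cc3)nn2)C(OCc2ccccc2)=C1OCc1ccccc1` is the next compound. Its change from compound 3 is (((4-chlorophenyl)sulfonyl)amino)methyl in place of 4-methylphenyl on an aromatic carbon. The step from compound 2 to compound 3 bears on it in reverse and was at least modest, so a large move to a lower number is expected. Compound 1 carries a closely related group on the same position and gives 3390 nM, which anchors the expectation. The step of an at least 25-fold lower number from compound 3 to compound 4 (1.39 log units; beyond the scatter) is therefore expected to be large. For compound 4 the estimate in this assay is 4000 nM, within 1500 nM to 12000 nM.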

Compound 4, half-maximal inhibitory concentration: 4170 nM
The estimate for compound 4 lay 1.0-fold (0.02 log units) below the measured number, and the stated range covers the measured number.
By their numbers in this assay, from the lowest: compounds 1 and 4 (each within the scatter of the next); then compound 2. At a limit, above all of these: compound 3.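

In this assay compound 3 is recorded only as a limit, not a number: the limit of > 100000 nM in this assay, at which 1 of the 4 values shown sits.

On this aromatic carbon, (((4-chlorophenyl)sulfonyl)amino)methyl in place of 4-methylphenyl gives an at least 23-fold lower number from compound 3 to compound 4 (1.37 log units; beyond the scatter), and in place of the silicon-bearing group it gives a 2.9-fold lower number from compound 2 to compound 4 (0.46 log units; beyond the scatter). Hydrogen in place of fluoro on the aromatic ring of that group gives a 1.2-fold higher number from compound 1 to compound 4 (0.09 log units; within the scatter), so the fluoro makes no difference beyond the scatter in this pair.

The compounds shown do not separate the contributions of the sulfonyl, the amino hydrogen and the chloro within the entering group. On these data alone, a carboxylic acid or an amine on the same aromatic carbon, or a longer chain in place of the methyl link of the entering group, remains open.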